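The source may hold more compounds than are shown below. What is called first, only, known or untested is meant among the compounds shown, and "the series" means these compounds.

Compound 1 `COc1ccc(-c2nc(N)c3nn(-c4ccccc4)cc3n2)cc1` gives 33% in an assay on CHO cells for displacement of a labelled ligand from adenosine receptor A1 (Homo sapiens), read by scintillation counting, with a stated time of 120 min, tested at 1 uM; on this read-out lower numbers stand for less inhibition and higher numbers for more inhibition at the one concentration tested (going by the name of the read-out). With (pyridin-4-yl)carbonyl in place of hydrogen on a nitrogen on an aromatic ring, compound 2 `COc1ccc(-c2nc(NC(=O)c3ccncc3)c3nn(-c4ccccc4)cc3n2)cc1` gives 3%, a step of a number 30 percentage points lower from compound 1 to compound 2 (beyond the scatter). With (4-methoxyphenyl)carbonyl in place of that hydrogen, compound 3 `COc1ccc(C(=O)Nc2nc(-c3ccc(OC)cc3)nc3cn(-c4ccccc4)nc23)cc1` gives 3%, a step of a number 30 percentage points lower from compound 1 to compound 3 (beyond the scatter). The step of no change at the digits printed from compound 2 to compound 3 (within the scatter) shows no difference, so compound 3 stands level with compound 2, the two together at the bottom of the three numbers. Compound 4 `COc1ccc(-c2nc(NC(=O)c3ccccc3)c3nn(-c4ccccc4)cc3n2)cc1` differs from compound 3 by hydrogen in place of methoxy on an aromatic carbon. Among the compounds with values here, the step that bears on this is the one from compound 2 to compound 3, where a different group on the carbonyl carbon left the number unchanged. The expected step is therefore a number 1 percentage points higher from compound 3 to compound 4 (within the scatter), none beyond the scatter. Compound 4 is expected to give 4%, within 0% to 15%.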

Compound 4, a percentage reported as inhibition, at one concentration (the size of the read-out at that concentration, not a potency): 2%
Beside the measured number, compound 4's estimate is 2 percentage points above it; the measured number falls inside the stated range.
By their numbers in this assay, from the lowest: compounds 4, 2 and 3 (each within the scatter of the next); then compound 1.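

Losing the methoxy changes nothing that can be told apart in this assay (a number 1 percentage points lower from compound 3 to compound 4 (within the scatter)), and neither does swapping the ring on the carbonyl carbon (a number 1 percentage points lower from compound 2 to compound 4 (within the scatter)). An unsubstituted benzoyl group still gives the full drop (a number 31 percentage points lower from compound 1 to compound 4 (beyond the scatter)), so among these compounds the drop goes with the acyl group on the nitrogen and needs neither the methoxy nor the pyridine nitrogen. No measurement here explains why. Still open, on these data alone, is whether a chlorine or hydroxyl at that ring position would read differently. Also open, as far as these compounds go, is whether acetyl, with no ring on the carbonyl, would give the same drop.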